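The source may report more compounds than this note shows. Statements on the series, on what has been measured and on what is new or still open speak of the compounds shown alone.

Of the compounds shown here, three of one family have been tested so far in a functional assay on NCI-H460 cells (Homo sapiens) for antiproliferative activity, read by CCK-8 assay, with a stated time of 72 h, tested at 8 uM; a higher number here means a stronger effect of the compound at the concentration tested, a lower number a weaker effect. Compound 1, with the structure `CN1CCN(c2nc(Cl)nc3c2ncn3Cc2ccc(C(=O)Nc3ccccc3N)cc2)CC1`, gives 55.1%. Compound 2, with the structure `Nc1ccccc1NC(=O)/C=C/c1ccc(Cn2cnc3c(NC4CCCCC4)nc(Cl)nc32)cc1`, gives 24.9%. Compound 3, with the structure `CCCCn1cnc2c(Nc3ccccc3)nc(NCOCc3ccc(/C=C/C(=O)Nc4ccccc4N)cc3)nc21`, gives 34.2%. Compound 2 thus sits at the low end of the three numbers: its value and that of compound 3 lie within the usual scatter of each other, so no order between them can be read, whereas the value of compound 1 lies clearly higher.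

The next compound, compound 4, has the structure `Cc1ccc(Nc2nc(Cl)nc3c2ncn3Cc2ccc(/C=C/C(=O)Nc3ccccc3N)cc2)cc1`. It arises from compound 2 by a single change: 4-methylphenyl in place of cyclohexyl on a nitrogen on an aromatic ring. Among the compounds with values here, no measured pair of compounds separated by just this change exists, so the size of the step cannot be read from earlier data. Because compound 3 gives 34.2% and compound 1 gives 55.1%, both higher than compound 2, a modest upward step is expected, of about a number 11.1 percentage points higher from compound 2 to compound 4 (beyond the scatter), possibly still within the scatter. The estimate for compound 4 in this assay is 36%, within a range from 18% to 55%.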

Compound 4, a percentage reported as inhibition, at one concentration (the size of the read-out at that concentration, not a potency): 51.3%
For compound 4 the middle estimate is 15.3 percentage points below the measured one, and the stated range covers the measured number.
By their numbers in this assay, from the lowest: compounds 2 and 3 (each within the scatter of the next); then compounds 4 and 1 (each within the scatter of the next).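

On a nitrogen on an aromatic ring, 4-methylphenyl in place of cyclohexyl gives a number 26.4 percentage points higher from compound 2 to compound 4 (beyond the scatter) in this assay and so shows that what is attached at this position can change the read-out. Within the data shown here, the earlier compounds could not show this, as none of them differed in just one place, and this is the first direct reading of this position. Nothing available here explains the step.

From the compounds shown here alone, it remains open whether the aromatic ring alone accounts for the step or whether the methyl group contributes, a question that plain phenyl on this nitrogen, with the rest of compound 4 kept, would address. A methoxy group in place of that methyl, or a morpholine at this position, would show how much further the read-out can move.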